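This account rests on a few compounds, and the source may have more. Where it says the series, first, only, none or still open, it means among the compounds named here.

Compound 1, `Cc1ccc(C(=O)Nc2cccc(-c3oc4cc(-c5ccc(F)cc5)ccc4c(=O)c3O)c2)cc1`, gives 7110 nM in a functional assay on HCC1937 cells (Homo sapiens) for antiproliferative activity, read by CCK-8 assay, with a stated time of 72 h; on this read-out higher numbers stand for weaker inhibition and lower numbers for stronger inhibition.
Compound 2, `O=C(Nc1cccc(-c2oc3cc(-c4ccc(F)cc4)ccc3c(=O)c2O)c1)c1ccc(C(F)(F)F)cc1`, gives 7350 nM in this assay.
Compound 3, `COc1cccc(C(=O)Nc2cccc(-c3oc4cc(-c5ccc(F)cc5)ccc4c(=O)c3O)c2)c1`, gives 18900 nM in this assay.

Compound 3 stands highest of the three numbers in this assay; the nearest to it is compound 2, a 2.6-fold higher number from compound 2 to compound 3 (0.41 log units; beyond the scatter), and the furthest is compound 1, a 2.7-fold higher number from compound 1 to compound 3 (0.42 log units; beyond the scatter). Compound 4, `O=C(Nc1cccc(-c2oc3cc(-c4ccc(F)cc4)ccc3c(=O)c2O)c1)c1cccc(F)c1`, has not yet been measured. Its change from compound 3 is fluoro in place of methoxy on an aromatic carbon. Among the compounds with values here, no measured step swaps one group for another at this place on the ring. Within the data shown here, the one step that swaps a group without moving its place, a 1.0-fold higher number from compound 1 to compound 2 (0.01 log units; within the scatter), stayed within the scatter. The two steps that reach compound 3 change the group and its place at once, so they cannot separate the two effects. From this, the step to compound 4 is expected to be small, either within the scatter or a modest fall in the number. Compound 4 is therefore estimated at 14000 nM, with a range from 6000 nM to 32000 nM. That estimate means an expected step of a 1.4-fold lower number from compound 3 to compound 4 (0.13 log units; within the scatter).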

Compound 4, half-maximal inhibitory concentration: 6590 nM
Compound 4: middle estimate off by 2.1-fold (0.33 log units), on the high side; the range from low to high includes it.
By their numbers in this assay, from the lowest: compounds 4, 1 and 2 (each within the scatter of the next); then compound 3.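

In this assay, within the data shown here, the exchange of methoxy for fluoro, on the same aromatic carbon, gives a 2.9-fold lower number from compound 3 to compound 4 (0.46 log units; beyond the scatter) and so shows what no earlier step could: a change of group alone, with its place held, moves the number beyond the scatter here. The other two steps, a 1.1-fold lower number from compound 2 to compound 4 (0.05 log units; within the scatter) and a 1.1-fold lower number from compound 1 to compound 4 (0.03 log units; within the scatter) both stay within the scatter, so the place of the group does not by itself set compound 3 apart, and its higher number goes with methoxy at this place. Nothing measured here explains this difference between methoxy and fluoro.

With only these two groups shown at this place, it remains open whether methoxy alone stands apart. A chloro, a hydroxyl or an amine on the same carbon could show whether other groups match fluoro or methoxy.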